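Chloro in place of 4-aminophenyl on compound 2

The source may report more compounds than this note shows. Statements on the series, on what has been measured and on what is new or still open speak of the compounds shown alone.

Measured in a functional assay on MDA-MB-231 cells (Homo sapiens) for inhibition, read by MTT assay, with a stated time of 72 h; a higher number here means a weaker inhibitor, a lower number a stronger inhibitor:
Compound 1 (`CC(C)(C)n1cc2c(n1)C(=O)CC1(CCN(C(=O)c3cc(-c4ccc(Cl)cc4)nc4ccccc34)CC1)O2`): > 10000 nM, a limit.
Compound 2 (`CC(C)(C)n1cc2c(n1)C(=O)CC1(CCN(C(=O)c3cc(-c4ccc(N)cc4)nc4ccccc34)CC1)O2`): 4960 nM
Compound 3 (`Cc1cc(C(=O)N2CCC3(CC2)CC(=O)c2nn(C(C)(C)C)cc2O3)c2ccccc2n1`): 4860 nM

Compound 2 stands level with compound 3, with a 1.0-fold lower number from compound 2 to compound 3 (0.01 log units; within the scatter), and the remaining value is a limit. Compound 4 (`CC(C)(C)n1cc2c(n1)C(=O)CC1(CCN(C(=O)c3cc(Cl)nc4ccccc34)CC1)O2`) has chloro in place of 4-aminophenyl on an aromatic carbon, next to the ring nitrogen (chloro in place of 4-aminophenyl on an aromatic carbon). The step to compound 3 is the closest guide, since methyl replaces the same group there without a change beyond the scatter. Two further steps concern the 4-chlorophenyl of compound 1 and bear only loosely: an at least 2.0-fold lower number from compound 1 to compound 2 (0.30 log units; that floor lies within the scatter) and an at least 2.0-fold lower number from compound 1 to compound 3 (0.31 log units; beyond the scatter). In this assay no step beyond the scatter is therefore expected, though the upper side carries more risk. The expected step is a 1.2-fold higher number from compound 2 to compound 4 (0.08 log units; within the scatter). For compound 4 the estimated value is 6000 nM, with an expected range of 3000 nM to 15000 nM.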

Compound 4, half-maximal inhibitory concentration: 9220 nM
Compound 4: the middle estimate sits 1.5-fold (0.19 log units) below what was measured, and the stated range covers the measured number.
By their numbers in this assay, from the lowest: compounds 3, 2 and 4 (each within the scatter of the next). At a limit, above all of these: compound 1.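

In this assay a lone chloro on this aromatic carbon, in place of the 4-aminophenyl, gives a 1.9-fold higher number from compound 2 to compound 4 (0.27 log units; within the scatter), and in place of the methyl, it gives a 1.9-fold higher number from compound 3 to compound 4 (0.28 log units; within the scatter). Across these three compounds, then, the six-membered aromatic ring of carbon only is not needed to hold the number at this level. The remaining step is an at least 1.0-fold lower number from compound 1 to compound 4 (0.03 log units; that floor lies within the scatter), and it cannot be read further, since compound 1 stands at a limit: the limit of > 10000 nM in this assay, at which 1 of the 4 values shown sits.

From the compounds shown here alone, whether an amine, a carboxylic acid or a longer chain on this carbon would give a step beyond the scatter stays open. So does whether any group here can bring the number clearly below that of compound 3 (4860 nM).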